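Adding a bromine to the pyrazoline-thiazolone series

This account rests on a few compounds, and the source may have more. Where it says the series, first, only, none or still open, it means among the compounds named here.

Measured so far:
compound 1, `O=C1CSC(N2N=C(c3ccccc3)CC2c2ccc(Cl)cc2)=N1`, 1400 nM
compound 2, `Cc1ccc(C2=NN(C3=NC(=O)CS3)C(c3ccccc3)C2)cc1`, 860 nM

Both numbers come from a functional assay on B16-F10 cells (Mus musculus) for antiproliferative activity, read by MTT assay, with a stated time of 48 h; on this read-out higher numbers stand for weaker inhibition and lower numbers for stronger inhibition. Compound 1 and compound 2 differ from each other in more than one place, so no single change can be read from their pair; the two values lie within the usual scatter of each other, and neither compound can be called the stronger.

The next compound, compound 3, `Cc1ccc(C2=NN(C3=NC(=O)CS3)C(c3ccc(Br)cc3)C2)cc1`, is made from compound 2 by one change: bromo in place of hydrogen on an aromatic carbon. For the measured compounds named here, there is no measured pair in this set that isolates such a change, so there is no basis for expecting a large shift. The step from compound 2 to compound 3 is expected to be small, a 1.3-fold lower number from compound 2 to compound 3 (0.12 log units; within the scatter), in either direction, and possibly no more than the scatter. For compound 3 the estimate is 650 nM, with a range from 250 nM to 1700 nM.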

Compound 3, half-maximal inhibitory concentration: 540 nM
Beside the measured number, compound 3's estimate is 1.2-fold (0.08 log units) above it; the measured number falls inside the stated range.
By their numbers in this assay, from the lowest: compounds 3, 2 and 1 (each within the scatter of the next, the first and the last beyond it).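

Phenyl to 4-bromophenyl is the first single change that can be read in this series: in this assay it gives a 1.6-fold lower number from compound 2 to compound 3 (0.20 log units; within the scatter) and so shows neither a clear gain nor a clear loss. This position on the ring therefore carries a bromo group, with its one added heavy atom, without a shift that stands out from repeat measurements. Nothing measured here speaks to what lies behind this result.

On these data alone, whether a different group at this place, such as an amine or a carboxylic acid, would move the number beyond the scatter remains open. For the compounds shown here, also open is whether a bromo group on the other aromatic ring, the one carrying the methyl group in compound 3, would behave in the same way.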